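Phenyl to propyl on the hydroxy-bearing chain of compound 1

The compounds below may be only part of what the source reports. "The series", "measured", "known", "first", "only" and "open" are said of these compounds alone.

Among the measured compounds shown here, compound 1 `C#CCOC(=O)C1=C(N)Oc2ccc(-c3cc(OC)cc(OC)c3)cc2C1CC(O)c1ccccc1` is the weaker of the two measured members: in a functional assay on HL-60 cells (Homo sapiens) for inhibition, with a stated time of 48 h (a higher number here means a weaker inhibitor, a lower number a stronger inhibitor), compound 1 gives 100000 nM, the higher of the two numbers recorded. Compound 2 `C#CCOC(=O)CC1C(C(=O)OCC#C)=C(N)Oc2ccc(-c3cc(OC)cc(OC)c3)cc21` gives 1160 nM in this assay. For the measured compounds named here, the one measured step, an 86-fold lower number from compound 1 to compound 2 (1.94 log units; beyond the scatter), replaces the whole hydroxy(phenyl)methyl group and so speaks only indirectly to the change at hand. Compound 3 `C#CCOC(=O)C1=C(N)Oc2ccc(-c3cc(OC)cc(OC)c3)cc2C1CC(O)CCC` differs from compound 1 by propyl in place of phenyl on a saturated chain carbon bound to an oxygen on a saturated carbon and a saturated chain carbon; the hydroxy group and the chain are kept. Going by the values given here, no measured pair isolates this exchange, so the direction in this assay cannot be read from the data. Compound 3 is therefore expected to stay near compound 1, with no change at the digits printed from compound 1 to compound 3 (within the scatter) as the estimated step, and an estimated value of 100000 nM in this assay, within 20000 nM to 300000 nM, with a real chance that only a limit is reported.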

Compound 3, half-maximal inhibitory concentration: 46600 nM
Beside the measured number, compound 3's estimate is 2.1-fold (0.33 log units) above it, and the stated range covers the measured number.
By their numbers in this assay, from the lowest: compound 2; then compound 3; then compound 1.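

In this assay, among the compounds shown here, phenyl to propyl is the first exchange that keeps the hydroxy-bearing chain and alters only its end: a 2.1-fold lower number from compound 1 to compound 3 (0.33 log units; beyond the scatter), a modest step showing that the six-membered aromatic ring is not needed at this place for the measured inhibition. The gain is small beside the large step that remains at the saturated chain carbon bound to a saturated ring carbon, a 40-fold higher number from compound 2 to compound 3 (1.60 log units; beyond the scatter), so 1-hydroxybutyl stays far from propargyloxycarbonyl there. No supporting measurement accounts for either step.

A single alkyl group cannot separate the loss of the aromatic ring from the choice of chain, and a longer chain such as hexyl or a cyclohexyl group at this place would help to tell them apart. As far as these compounds go, the role of the hydroxy group also remains open, and an amine in its place would test it.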